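A few compounds are considered here, and "the series" means these few. Any claim that something is new, unique, unknown or untested is made for them only; others in the source may bear on it.

Measured compounds:
Compound 1 `CCS(=O)(=O)N1CCC(CN(C2Cc3cc(C#N)ccc3N(Cc3cncn3C)C2)S(=O)(=O)c2ccccn2)CC1`: 0.1 10^-6 cm/s
Compound 2 `Cn1cncc1CN1CC(N(CC2CCN(C(=O)c3cccs3)CC2)S(=O)(=O)c2ccccn2)Cc2cc(C#N)ccc21`: 0.5 10^-6 cm/s
Compound 3 `Cn1cncc1CN1CC(N(CC2CCN(C(=O)Nc3ccc(Br)cc3)CC2)S(=O)(=O)c2ccccn2)Cc2cc(C#N)ccc21`: 0.6 10^-6 cm/s

In an ADME assay on Caco-2 cells (Homo sapiens) for permeability, in the apical to basolateral direction (on this read-out higher numbers stand for higher permeability and lower numbers for lower permeability), compound 1 gives 0.1 10^-6 cm/s, the lowest of the three numbers; compound 2 gives 0.5 10^-6 cm/s and compound 3 gives 0.6 10^-6 cm/s. The two measured steps that start from compound 1 both leave the ethylsulfonyl group: a 5.0-fold higher number from compound 1 to compound 2 (0.70 log units; beyond the scatter) and a 6.0-fold higher number from compound 1 to compound 3 (0.78 log units; beyond the scatter). Between the other two compounds the change is a 1.2-fold higher number from compound 2 to compound 3 (0.08 log units; within the scatter).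

Compound 4 `Cn1cncc1CN1CC(N(CCn2cccc2)S(=O)(=O)c2ccccn2)Cc2cc(C#N)ccc21` differs from compound 1 in one place: (1H-pyrrol-1-yl)methyl in place of 1-(ethylsulfonyl)piperidin-4-yl on a saturated chain carbon bound to a sulfonamide nitrogen. Among the compounds with values here, no measured step removes the whole 1-(ethylsulfonyl)piperidin-4-yl unit, so the two steps above bear on it only in that each removes the ethylsulfonyl part and each raises the number by a modest amount. On that basis the estimate for compound 4 in this assay is a modest rise of similar size, an 8.0-fold higher number from compound 1 to compound 4 (0.90 log units; beyond the scatter), with the expected value 0.8 10^-6 cm/s and a range from 0.2 10^-6 cm/s to 3 10^-6 cm/s.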

Compound 4, apparent permeability: 12.4 10^-6 cm/s
For compound 4 the middle estimate is 16-fold (1.19 log units) below the measured one; measured number outside the range, above it.
By their numbers in this assay, from the lowest: compound 1; then compounds 2 and 3 (each within the scatter of the next); then compound 4.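

In this assay, the exchange of the entire 1-(ethylsulfonyl)piperidin-4-yl unit for (1H-pyrrol-1-yl)methyl gives a 120-fold higher number from compound 1 to compound 4 (2.09 log units; beyond the scatter), a large step. The earlier steps shown here changed only the group on the ring nitrogen and stayed modest, so this place, on a saturated chain carbon bound to a sulfonamide nitrogen, can carry a far larger change in the number than those steps showed. No measurement here gives a reason for the size of this step.

The step swaps a six-membered non-aromatic ring for a five-membered aromatic ring and also removes the ethylsulfonyl group, and the compounds shown do not separate these changes. Going by these compounds, it stays open whether a phenyl ring, a plain butyl chain or an unsubstituted piperidin-4-yl at this place would give a number like that of compound 4.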